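Halogenated benzyl swap on a shared core

The compounds below may be only part of what the source reports. "The series", "measured", "known", "first", "only" and "open" are said of these compounds alone.

Compound 2 `C[C@H](NC(=O)c1c(Cc2cccc(Cl)c2)sc2c1CCOC2)c1ccc(C(=O)O)cc1` gives 3.2 nM in a functional assay on CHO/Galpha16 cells for antagonist activity at prostaglandin E2 receptor EP4 subtype (Homo sapiens), read by calcium flux, with a stated time of 15 min (a higher number here means a weaker inhibitor, a lower number a stronger inhibitor), the higher of the two numbers in hand; compound 1 `O=C(O)c1ccc(C2(NC(=O)c3c(Cc4cccc(C(F)(F)F)c4)sc4c3CCOC4)CC2)cc1` gives 1 nM in this assay. Compound 3 `C[C@H](NC(=O)c1c(Cc2cc(F)c(Cl)cc2Cl)sc2c1CCOC2)c1ccc(C(=O)O)cc1` has not yet been measured. It differs from compound 2 by 2,4-dichloro-5-fluorophenyl in place of 3-chlorophenyl on a saturated chain carbon bound to an aromatic carbon. Going by the values given here, with no step between measured compounds to lean on, no shift beyond the usual scatter is expected in this assay, in either direction. Compound 3 is therefore expected to give about 3.5 nM in this assay, within 1.2 nM to 10 nM, a step of a 1.1-fold higher number from compound 2 to compound 3 (0.04 log units; within the scatter) estimated to be small.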

Compound 3, half-maximal inhibitory concentration: 2.5 nM
For compound 3 the middle estimate is 1.4-fold (0.15 log units) above the measured one, within the range that was stated.
By their numbers in this assay, from the lowest: compound 1; then compounds 3 and 2 (each within the scatter of the next).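

In this assay, 2,4-dichloro-5-fluorophenyl in place of 3-chlorophenyl on a saturated chain carbon bound to an aromatic carbon gives a 1.3-fold lower number from compound 2 to compound 3 (0.11 log units; within the scatter) and so shows that this position accepts the larger, more heavily halogenated ring without a shift beyond the scatter. Because this is a single step, it shows tolerance for this one replacement and not a trend. No measurement at hand explains why the step is so small.

The compounds shown leave open whether a ring carrying a methoxy group or an amine would stay as close to compound 2. They also leave open how an unsubstituted phenyl would behave here.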